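The source may hold more compounds than are shown below. What is called first, only, known or untested is meant among the compounds shown, and "the series" means these compounds.

Measured compounds:
compound 1 `O=C1CSC(c2c(Cl)cccc2Cl)N1CCN1CCCCC1` — 75%
compound 2 `O=C1CSC(c2ccc(O)cc2)N1CCN1CCCCC1` — 87%
compound 3 `Cc1ccc(C2SCC(=O)N2CCN2CCCCC2)cc1` — 85%

In an ADME assay on Vero cells (Chlorocebus sabaeus) for cytotoxicity, read by neutral red uptake, tested at 197 ug/mL (a lower number here means a stronger effect, a higher number a weaker effect of the compound at the concentration tested), compound 1 gives 75%. Against compound 2 this number is lower by a gap beyond the scatter; against compound 3 the gap is within the scatter, so no order between compound 1 and compound 3 is claimed. Among the measured compounds shown here, the only measured step in this assay, a number 2 percentage points lower from compound 2 to compound 3 (within the scatter), is within the scatter and concerns a different aromatic group.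

Compound 4 `O=C1CSC(c2ccccc2Cl)N1CCN1CCCCC1` is not yet measured. It differs from compound 1 by hydrogen in place of chloro on an aromatic carbon. For the measured compounds named here, no measured step bears on the loss of a chloro group, and the one step seen, from compound 2 to compound 3, was within the scatter. A step of a number 5 percentage points higher from compound 1 to compound 4 (within the scatter) is therefore expected, with no change beyond the scatter. Compound 4 is expected to give 80% in this assay, in the range 68% to 92%.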

Compound 4, a percentage reported as activity, at one concentration (the size of the read-out at that concentration, not a potency): 71%
Beside the measured number, compound 4's estimate is 9 percentage points above it; low and high end bracket the measured number.
By their numbers in this assay, from the lowest: compounds 4, 1, 3 and 2 (each within the scatter of the next, the first and the last beyond it).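

In this assay hydrogen in place of chloro on an aromatic carbon stays within the scatter (a number 4 percentage points lower from compound 1 to compound 4 (within the scatter)), so this change at this position does not separate the two chlorinated compounds. Changing the aromatic group itself does reach beyond the scatter, both for 2-chlorophenyl in place of 4-methylphenyl (a number 14 percentage points lower from compound 3 to compound 4 (beyond the scatter)) and for 2-chlorophenyl in place of 4-hydroxyphenyl (a number 16 percentage points lower from compound 2 to compound 4 (beyond the scatter)). Nothing available accounts for these steps.

Open, going by these compounds, is how an amine or a carboxylic acid on the aromatic carbon would read in place of chloro.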